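This account rests on a few compounds, and the source may have more. Where it says the series, first, only, none or still open, it means among the compounds named here.

Three compounds share one core and differ only in the group carried on the amine nitrogen. Compound 1 `CCCCCN[C@@H]1C=C[C@H](O)[C@H](O)[C@H]1O` bears a pentyl chain; in an assay for inhibition of beta-galactosidase (Homo sapiens), read by fluorescence, with a stated time of 30 min, at pH 4.5 (on this read-out higher numbers stand for weaker inhibition and lower numbers for stronger inhibition), compound 1 gives 19000 nM. Compound 3 `CC(C)CN[C@@H]1C=C[C@H](O)[C@H](O)[C@H]1O` bears an isobutyl group, and compound 3 gives 41000 nM, the higher of the two numbers shown; the only structural difference between them is the step of a 2.2-fold higher number from compound 1 to compound 3 (0.33 log units; beyond the scatter). Compound 2 `OCCCN[C@@H]1C=C[C@H](O)[C@H](O)[C@H]1O` bears a 3-hydroxypropyl group, and compound 2 gives only a limit of the assay, > 1000000 nM (the limit of > 1000000 nM in this assay, at which 1 of the 3 values shown sits). Compound 4 `CCC(CC)CN[C@@H]1C=C[C@H](O)[C@H](O)[C@H]1O` is not yet measured; it differs from compound 3 by pentan-3-yl in place of isopropyl on a saturated chain carbon bound to an amine nitrogen. The step that bears most on this change is a 2.2-fold higher number from compound 1 to compound 3 (0.33 log units; beyond the scatter), where a shorter branched group raised the number modestly; the change to compound 4 goes the other way, making the branched group longer. The steps of an at least 52-fold higher number from compound 1 to compound 2 (1.72 log units; beyond the scatter) and an at least 24-fold lower number from compound 2 to compound 3 (1.38 log units; beyond the scatter) involve a hydroxyl and say less about it. The expected step is therefore a 1.6-fold lower number from compound 3 to compound 4 (0.21 log units; within the scatter), a modest lowering or none beyond the scatter. Compound 4 is estimated at 25000 nM, with a range from 8000 nM to 80000 nM.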

Compound 4, half-maximal inhibitory concentration: 15000 nM
The estimate for compound 4 lay 1.7-fold (0.22 log units) above the measured number; measured number inside the range.
By their numbers in this assay, from the lowest: compounds 4 and 1 (each within the scatter of the next); then compound 3. At a limit, above all of these: compound 2.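

In this assay, enlarging the group on the saturated chain carbon bound to the amine nitrogen from isopropyl to pentan-3-yl gives a 2.7-fold lower number from compound 3 to compound 4 (0.44 log units; beyond the scatter), so a larger branched carbon group is accepted at this position and improves on the smaller one. The branched pentan-3-yl group and the straight chain of compound 1 cannot be told apart, with a 1.3-fold lower number from compound 1 to compound 4 (0.10 log units; within the scatter), so the data show no separate gain from branching. The step of an at least 66-fold lower number from compound 2 to compound 4 (1.82 log units; beyond the scatter) gives only a minimum size, as compound 2 sits at a limit of the assay rather than at a number: the limit of > 1000000 nM in this assay, at which 1 of the 4 values shown sits.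

From the compounds shown here alone, it remains open whether a still larger carbon group, such as a cyclohexyl ring or a longer chain, would lower the number further. Also open, going by these compounds, is how an amine or a carboxylic acid at the end of the chain would compare with the hydroxyl of compound 2.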